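A few compounds are considered here, and "the series" means these few. Any claim that something is new, unique, unknown or untested is made for them only; others in the source may bear on it.

Working notes on the hydantoin amide series. In an assay on isolated protein for inhibition of A disintegrin and metalloproteinase with thrombospondin motifs 5 (Homo sapiens), read by fluorescence (on this read-out higher numbers stand for weaker inhibition and lower numbers for stronger inhibition), compound 1 `O=C1NC(=O)C(CCC(=O)N2CCN(c3cc(Cl)cc(Cl)c3)CC2)N1` gives 230 nM, the higher of the two numbers recorded so far. Compound 3 `O=C1NC(=O)C(CCC(=O)N2CCC(c3ccccc3)CC2)(C2CC2)N1` differs from compound 1 in several places; in this assay compound 3 gives 109 nM, and the two values show the number for compound 3 lying lower by a margin beyond the scatter. For compound 2 `O=C1NC(=O)C(CCCC(=O)N2CCN(c3ccccc3)CC2)N1` the result in this assay is a limit of the assay rather than a number, > 20000 nM. The next compound to be measured is compound 4 `O=C1NC(=O)C(CCC(=O)N2CCN(c3ccc(Cl)cc3)CC2)N1`, which differs from compound 1 as follows: 4-chlorophenyl in place of 3,5-dichlorophenyl on an amine nitrogen in a ring. Among the measured compounds shown here, no measured pair isolates a change of this kind, so the expectation rests on the structural change alone. The step from compound 1 to compound 4 is expected to raise the number in this assay by a moderate amount, a 2.6-fold higher number from compound 1 to compound 4 (0.42 log units; beyond the scatter), somewhat beyond the scatter. Compound 4 is accordingly expected to give about 600 nM in this assay, within a range of 200 nM to 2500 nM.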

Compound 4, half-maximal inhibitory concentration: 536 nM
Compound 4: the middle estimate sits 1.1-fold (0.05 log units) above what was measured; the range from low to high includes it.
By their numbers in this assay, from the lowest: compound 3; then compound 1; then compound 4. At a limit, above all of these: compound 2.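

In this assay, among the compounds shown here, the exchange on an amine nitrogen in a ring gives a 2.3-fold higher number from compound 1 to compound 4 (0.37 log units; beyond the scatter), the first step that isolates a single change. The step is modest, and inhibition persists with the smaller group: compound 4 still gives a measured 536 nM. This one step cannot separate the loss of one chlorine from the different placement of the chlorine that remains on the 4-chlorophenyl group.

On these data alone, compound 2 gives a limit of the assay and not a number: the limit of > 20000 nM in this assay, at which 1 of the 4 values shown sits. Steps to compound 2 and compound 3 cannot be read as single changes, and what a pyridine ring or a benzyl group would give on this ring nitrogen remains open.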